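Removing the chloro from the aryl of compound 2

The compounds below may be only part of what the source reports. "The series", "measured", "known", "first", "only" and "open" are said of these compounds alone.

Compound 2 `O=C(O)Cc1sc(C(c2ccc(F)cc2)c2ccc(F)cc2)nc1-c1ccc(Cl)cc1` gives 180 nM in an in vitro functional assay on HEK285-7 cells for antagonist activity at prostaglandin D2 receptor 2 (Homo sapiens), read by BRET and beta-arrestin recruitment (on this read-out lower numbers stand for stronger inhibition and higher numbers for weaker inhibition), the higher of the two numbers recorded so far; compound 1 `O=C(O)Cc1sc(C(c2ccccc2)c2ccc(F)cc2)nc1-c1ccc(Cl)cc1` gives 36 nM. Going by the values given here, the single measured step, a 5.0-fold higher number from compound 1 to compound 2 (0.70 log units; beyond the scatter), concerns a change on a different ring and therefore does not bear on the change now considered. Compound 3 `O=C(O)Cc1sc(C(c2ccc(F)cc2)c2ccc(F)cc2)nc1-c1ccccc1` differs from compound 2 by hydrogen in place of chloro on an aromatic carbon. No measured step in this assay tests removal of the chloro from this ring, so neither the direction nor the size of the step can be read from the numbers shown, and the expectation rests on the change alone. The expected step is a 2.2-fold higher number from compound 2 to compound 3 (0.35 log units; beyond the scatter), a modest weakening at most, with a wide uncertainty. Compound 3 is therefore estimated to give about 400 nM in this assay, with a range of 120 nM to 1300 nM.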

Compound 3, half-maximal inhibitory concentration: 240 nM
For compound 3 the middle estimate is 1.7-fold (0.22 log units) above the measured one; measured number inside the range.
By their numbers in this assay, from the lowest: compound 1; then compounds 2 and 3 (each within the scatter of the next).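

In this assay, the change from 4-chlorophenyl to phenyl gives a 1.3-fold higher number from compound 2 to compound 3 (0.12 log units; within the scatter), so on the background of compound 2 this read-out does not separate chloro from hydrogen at this position. Going by these compounds alone, this is the first measured step at this place; the only earlier step, a 5.0-fold higher number from compound 1 to compound 2 (0.70 log units; beyond the scatter), lies on a different ring and, unlike this one, is beyond the scatter. No evidence at hand bears on the reason for this result.

On these data alone, it remains open whether the same change would also stay within the scatter on the background of compound 1, where the earlier step gave the lower number. Also open, as far as these compounds go, is how this position responds to groups other than chloro and hydrogen, such as a methoxy group, an amine or a nitrile.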